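Growing the Alkyl Chain on the Aryl Amide

The source may report more compounds than this note shows. Statements on the series, on what has been measured and on what is new or still open speak of the compounds shown alone.

Measured so far:
Compound 1, `Cc1ccc(C(=O)N[C@@H]2[C@@H](O)[C@H](n3cnc4c(NC5CCCC5)ncnc43)O[C@@H]2C)cc1C`: in an assay on isolated protein for binding affinity to adenosine receptor A1 (Rattus norvegicus), in the absence of a further agent (on this read-out higher numbers stand for weaker inhibition and lower numbers for stronger inhibition), compound 1 gives 236 nM.
Compound 2, `CCc1ccc(C(=O)N[C@@H]2[C@@H](O)[C@H](n3cnc4c(NC5CCCC5)ncnc43)O[C@@H]2C)cc1`: in this assay compound 2 gives 240 nM.

Within the data shown here, compound 2 carries the higher of the two numbers measured, but its only neighbour, compound 1, sits so close that the difference means nothing: a 1.0-fold higher number from compound 1 to compound 2 (0.01 log units; within the scatter). Compound 3, `CC(C)c1ccc(C(=O)N[C@@H]2[C@@H](O)[C@H](n3cnc4c(NC5CCCC5)ncnc43)O[C@@H]2C)cc1`, differs from compound 2 by methyl in place of hydrogen on a saturated chain carbon bound to an aromatic carbon and a saturated chain carbon. Among the measured compounds shown here, the single measured step, swapping 4-ethylphenyl for 3,4-dimethylphenyl on the carbonyl carbon, also reshuffled carbon on the aryl amide and moved the number not at all beyond the scatter, so it bears on this change only loosely. For the measured compounds named here, with no step showing that extra carbon here shifts binding, the expected step from compound 2 to compound 3 is no change at the digits printed from compound 2 to compound 3 (within the scatter), nothing beyond the scatter in either direction. Compound 3 is therefore estimated at 240 nM in this assay, with a range from 100 nM to 600 nM.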

Compound 3, inhibition constant: 270 nM
Compound 3: middle estimate off by 1.1-fold (0.05 log units), on the low side; measured number inside the range.
By their numbers in this assay, from the lowest: compounds 1, 2 and 3 (each within the scatter of the next).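

In this assay, adding methyl on the saturated chain carbon, which turns 4-ethylphenyl into 4-isopropylphenyl, gives a 1.1-fold higher number from compound 2 to compound 3 (0.05 log units; within the scatter), so this first branching of the chain brings no readable change. Putting 4-isopropylphenyl in place of 3,4-dimethylphenyl on the carbonyl carbon gives a 1.1-fold higher number from compound 1 to compound 3 (0.06 log units; within the scatter), so all three alkyl patterns on the aryl amide now lie within the scatter of one another, a flat picture that holds for these compounds alone. No outside evidence bears on this result.

Still open, as far as these compounds go, is whether a bulkier alkyl group such as tert-butyl, or a longer chain such as n-butyl, would move the number beyond the scatter at this place. Also open, from the compounds shown here alone, is whether a group that is not pure hydrocarbon, such as methoxy or an amine, would do so.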